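The source may report more compounds than this note shows. Statements on the series, on what has been measured and on what is new or still open speak of the compounds shown alone.

Measured:
compound 1 `COc1ccccc1-n1cc(COc2ccc3c(c2)CCC3)nn1` — 19.8%
compound 2 `O=C(Cn1cc(COc2ccc3c(c2)CCC3)nn1)Nc1ccccc1Cl` — "not determined" (no result reported)

Among the measured compounds shown here, in an ADME assay on HEK293 cells (Homo sapiens) for inhibition, read by MTT assay, with a stated time of 48 h, tested at 25 uM (a higher number here means more inhibition at the concentration tested (going by the name of the read-out), a lower number less inhibition), compound 1 gives 19.8%, the only number; compound 2 has no result, so nothing can be read from it. For the measured compounds named here, no step between measured compounds exists here.

Compound 3 `Fc1ccccc1-n1cc(COc2ccc3c(c2)CCC3)nn1` differs from compound 1 as follows: fluoro in place of methoxy on an aromatic carbon. Going by the values given here, with a single measured value and no step to lean on, the step in this assay from compound 1 to compound 3 is expected to be small, in no firm direction, likely within the scatter: a number 0.2 percentage points higher from compound 1 to compound 3 (within the scatter). Compound 3 is estimated at 20%, with a range from 5% to 38%.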

Compound 3, a percentage reported as inhibition, at one concentration (the size of the read-out at that concentration, not a potency): 21%
For compound 3 the middle estimate is 1 percentage points below the measured one; the range from low to high includes it.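

In this assay, among the compounds shown here, the first readable step at this place, on an aromatic carbon ortho to a large group, is a number 1.2 percentage points higher from compound 1 to compound 3 (within the scatter). Going from 2-methoxyphenyl to 2-fluorophenyl removes a hydrogen-bond acceptor and one heavy atom, yet the read-out does not tell the two groups apart. Nothing at hand gives a reason for this result.

Steps involving compound 2 cannot be read, so its chlorophenyl amide side chain stays uninterpreted. On these data alone, whether an amine or a carboxylic acid at this place would separate from fluoro and methoxy remains open.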